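The source may hold more compounds than are shown below. What is called first, only, known or untested is meant among the compounds shown, and "the series" means these compounds.

Compound 1 `O=C(Nc1cccc(-c2nc(-c3ccc(NC(=O)c4cccnc4)cc3Cl)no2)c1)c1ccccc1` gives 12800 nM in a functional assay on MDA-MB-231 cells (Homo sapiens) for antiproliferative activity, read by MTT assay, with a stated time of 72 h; a lower number here means a stronger inhibitor, a higher number a weaker inhibitor. Replacing the phenyl on the carbonyl carbon by an arylamino lowers the number: compound 2 `Cc1ccc(NC(=O)Nc2cccc(-c3nc(-c4ccc(NC(=O)c5cccnc5)cc4Cl)no3)c2)cc1` gives 3500 nM, a step of a 3.7-fold lower number from compound 1 to compound 2 (0.56 log units; beyond the scatter), and compound 3 `O=C(Nc1cccc(-c2nc(-c3ccc(NC(=O)c4cccnc4)cc3Cl)no2)c1)Nc1cccc(C(F)(F)F)c1` gives 1900 nM, a step of a 6.7-fold lower number from compound 1 to compound 3 (0.83 log units; beyond the scatter). Compound 3 has the lowest number of the three, but the step of a 1.8-fold lower number from compound 2 to compound 3 (0.27 log units; within the scatter) is within the scatter, so only its gap to compound 1 is secure.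

Compound 4 `COc1ccc(NC(=O)Nc2cccc(-c3nc(-c4ccc(NC(=O)c5cccnc5)cc4Cl)no3)c2)cc1C(F)(F)F` differs from compound 3 by methoxy in place of hydrogen on an aromatic carbon. Going by the values given here, no measured step changes a substituent on that ring; the only step touching it, a 1.8-fold lower number from compound 2 to compound 3 (0.27 log units; within the scatter), swaps the whole aryl and stays within the scatter. A step of a 1.1-fold lower number from compound 3 to compound 4 (0.05 log units; within the scatter) is therefore expected, no change beyond the scatter, and compound 4 is estimated at 1700 nM, within 700 nM to 4500 nM.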

Compound 4, half-maximal inhibitory concentration: 1700 nM
Beside the measured number, compound 4's estimate shows no gap at the digits printed; the measured number falls inside the stated range.
By their numbers in this assay, from the lowest: compounds 4, 3 and 2 (each within the scatter of the next, the first and the last beyond it); then compound 1.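

In this assay, going by these compounds alone, methoxy ortho to a trifluoromethyl group and para to a large group is the first change to a substituent on this ring, and it is tolerated: a 1.1-fold lower number from compound 3 to compound 4 (0.05 log units; within the scatter). Against 4-methylphenyl, 4-methoxy-3-(trifluoromethyl)phenyl gives a 2.1-fold lower number from compound 2 to compound 4 (0.31 log units; beyond the scatter), only just clearing the scatter, whereas a 1.8-fold lower number from compound 2 to compound 3 (0.27 log units; within the scatter) does not. No available evidence bears on the reason for either step. Still open, as far as these compounds go, is whether an amine, a carboxylic acid or ethoxy at this carbon would also leave the number unchanged. Also open, from the compounds shown here alone, is how methoxy behaves on this ring without the trifluoromethyl group.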